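Swapping the Phenyl Group on the Least Stable Compound

This account rests on a few compounds, and the source may have more. Where it says the series, first, only, none or still open, it means among the compounds named here.

In an ADME assay (liver) for metabolic stability, with Liver microsome (Canis lupus familiaris) as the target, read by LC-MS, using microsomes, with a stated time of 30 min, tested at 4 uM (a lower number here means that less of the compound is left, a higher number that more of the compound is left), compound 1 (`Cc1nc(N2CCN(C)CC2)c2nc(-c3ccccc3Cl)n(C3CC3)c2n1`) gives 98% and compound 2 (`CCN1CCN(c2nc(C)nc3c2nc(-c2ccccc2Cl)n3CC2CCOCC2)CC1`) gives 76% as its result. Compound 3 (`Cc1nc(N2CCN(C)CC2)c2nc(-c3cccc(Cl)c3)n(C3CCOCC3)c2n1`) stands at 45% as the lowest of the three, beyond the usual scatter from both others. Compound 4 (`Cc1nc(N2CCN(C)CC2)c2nc(-c3ccccc3F)n(C3CCOCC3)c2n1`) has 2-fluorophenyl in place of 3-chlorophenyl on an aromatic carbon. For the measured compounds named here, no two measured compounds differ in one place only, so any forecast here is loose. The entering group looks closer to the halogen-bearing phenyl of compound 2 at 76% in this test. An upward move beyond the scatter is therefore expected (a number 20 percentage points higher from compound 3 to compound 4 (beyond the scatter)). For compound 4 the estimated value is 65% with an expected range from 42% to 86% overall.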

Compound 4, percent of the compound remaining: 21%
Compound 4: middle estimate off by 44 percentage points, on the high side, outside the stated range (below it).
By their numbers in this assay, from the lowest: compound 4; then compound 3; then compound 2; then compound 1.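

For the compounds shown here, this is the first pair here that differs in one place only, so the phenyl group can be read on its own. With the oxan-4-yl group and the rest of the molecule unchanged, 2-fluorophenyl in place of 3-chlorophenyl gives in this assay a number 24 percentage points lower from compound 3 to compound 4 (beyond the scatter), so the choice of halogen-bearing phenyl at this aromatic carbon matters. Nothing available explains the fall.

Going by these compounds, the halogen and its ring position change together, so their separate shares remain open. On these data alone, how a plain phenyl group without halogen would fare here also remains open.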